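The compounds below may be only part of what the source reports. "The series", "measured", "known", "first", "only" and "open" are said of these compounds alone.

Measured so far:
Compound 1, `CC(=O)OC/C(=C\c1ccccc1F)C(=O)c1ccccc1`, gives 68700 nM in a functional assay on A549 cells (Homo sapiens) for inhibition, read by XTT assay, with a stated time of 48 h; a higher number here means a weaker inhibitor, a lower number a stronger inhibitor.
Compound 2, `C=C(C(=O)c1ccc(OC)cc1)C(OC(C)=O)c1ccccc1F`, gives 67300 nM in this assay.
Compound 3, `C=C(C(=O)c1ccc(OC)cc1)C(OC(=O)c1ccccc1)c1ccccc1F`, gives 73700 nM in this assay.

All three numbers sit close together, and the gaps between compound 3 and each of the other two lie within the scatter of this assay, so none of the three can be called stronger or weaker than another. Among the compounds with values here, the one step that has been measured, a 1.1-fold higher number from compound 2 to compound 3 (0.04 log units; within the scatter), swaps a phenyl for a methyl on a carbonyl carbon and leaves the number where it was.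

Compound 4, `C=C(C(=O)c1ccc(OC)cc1)C(OC(=O)c1ccccc1)c1ccccc1[N+](=O)[O-]`, has not yet been measured. It differs from compound 3 in one place: nitro in place of fluoro on an aromatic carbon. Within the data shown here, no measured step touches this part of the molecule, so nothing among the three compounds speaks directly for or against a change here. Among the measured compounds shown here, the only guide is the flatness of the numbers so far, which gives no reason to expect a large move in either direction.

On that basis the step of a 1.1-fold lower number from compound 3 to compound 4 (0.02 log units; within the scatter) is expected to stay within the scatter. For compound 4 the estimate in this assay is 70000 nM, with a range from 25000 nM to 200000 nM.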

Compound 4, half-maximal inhibitory concentration: 45500 nM
Compound 4: middle estimate off by 1.5-fold (0.19 log units), on the high side; low and high end bracket the measured number.
By their numbers in this assay, from the lowest: compounds 4, 2, 1 and 3 (each within the scatter of the next).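

Within the data shown here, the step of a 1.6-fold lower number from compound 3 to compound 4 (0.21 log units; within the scatter) is the first reading at this position, an aromatic carbon ortho to a large group, and it concerns the change from 2-fluorophenyl to 2-nitrophenyl. In this assay, then, replacing fluoro, a single heavy atom with no hydrogen-bond acceptors, by nitro, with three heavy atoms and two hydrogen-bond acceptors, gives no difference that can be told from the ordinary spread of repeated measurements, so this position accepts at least this one substantial swap without a readable effect. No further measurement accompanies this result, so the data offer no explanation for how the number behaves at this position.

With only fluoro and nitro shown here, it remains open whether a very different group on the same aromatic carbon, such as an amine or a carboxylic acid, would move the number beyond the scatter. As far as these compounds go, it also remains open whether the same swap from fluoro to nitro would behave alike in compound 2, which carries a methyl where compound 3 carries a phenyl on the carbonyl carbon.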